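A few compounds are considered here, and "the series" means these few. Any claim that something is new, unique, unknown or untested is made for them only; others in the source may bear on it.

Of the compounds shown here, two of a shared core have been measured in a functional assay on MDA-MB-231 cells (Homo sapiens) for antiproliferative activity, read by MTT assay, with a stated time of 24 h; a lower number here means a stronger inhibitor, a higher number a weaker inhibitor. Going by the values given here, compound 2 `COc1ccc(-c2cc(/C=C/C(=O)c3ccc(C)cc3)nc3cc(-c4ccccc4)nn23)cc1OC` gives 19800 nM, the lowest of the two numbers so far. Compound 1 `COc1ccc(/C=C/C(=O)c2cc(-c3ccc(OC)c(OC)c3)n3nc(-c4ccccc4)cc3n2)cc1` gives 22000 nM. Among the compounds with values here, the one step between them, a 1.1-fold lower number from compound 1 to compound 2 (0.05 log units; within the scatter), sits inside the usual scatter, so the two compounds cannot be told apart on these numbers.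

Compound 3 `COc1ccc(-c2cc(/C=C/C(=O)c3ccc(Cl)cc3)nc3cc(-c4ccccc4)nn23)cc1OC` is the next member. It differs from compound 2 by chloro in place of methyl on an aromatic carbon; cut one bond further out, this reads 2-((4-methylphenyl)carbonyl)ethenyl to 2-((4-chlorophenyl)carbonyl)ethenyl, the place being para to a large group on a six-membered aromatic ring of carbon only. Within the data shown here, no measured step touches this ring position, and the single step on record, from compound 1 to compound 2, changed a different part of the molecule and stayed within the scatter. With nothing to point either way, the expected step of a 1.1-fold lower number from compound 2 to compound 3 (0.04 log units; within the scatter) is none beyond the scatter. Compound 3 is therefore estimated at 18000 nM, with a range from 7000 nM to 45000 nM.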

Compound 3, half-maximal inhibitory concentration: 17100 nM
Beside the measured number, compound 3's estimate is 1.1-fold (0.02 log units) above it, and the stated range covers the measured number.
By their numbers in this assay, from the lowest: compounds 3, 2 and 1 (each within the scatter of the next).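

Going by these compounds alone, this is the first measured change at this ring position. Putting chloro in place of methyl, on an aromatic carbon para to a large group, gives a 1.2-fold lower number from compound 2 to compound 3 (0.06 log units; within the scatter) in this assay, so the two groups cannot be told apart on these numbers. The larger replacement of (2-(4-methoxyphenyl)ethenyl)carbonyl by 2-((4-chlorophenyl)carbonyl)ethenyl on an aromatic carbon gives a 1.3-fold lower number from compound 1 to compound 3 (0.11 log units; within the scatter), so this step does not separate its two compounds either, and no measurement is available to explain either result.

The groups compared at this position, methyl and chloro, each have one heavy atom and no hydrogen-bond donors or acceptors, so the result says little about how a very different group would behave there. Whether an amine, a carboxylic acid or a longer chain in place of the chloro would shift the number beyond the usual scatter remains open, as the three compounds shown give no sign of how much this position can affect activity.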